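A few compounds are considered here, and "the series" means these few. Any claim that something is new, unique, unknown or untested is made for them only; others in the source may bear on it.

Three analogues of the shared core differ only in the aryl group on the ring carbon that lies next to the ring oxygen. Compound 1 `CCC1=C(O)c2c(oc(-c3ccc(C(C)C)cc3)cc2=O)C(CC)(CC)C1=O` gives 1.08 uM in a functional assay on KBVIN cells (Homo sapiens) for antiproliferative activity, read by sulforhodamine B assay, with a stated time of 3 days; on this read-out lower numbers stand for an effect already at smaller amounts and higher numbers for an effect only at larger amounts of compound. Compound 2 `CCC1=C(O)c2c(oc(-c3ccccc3OC)cc2=O)C(CC)(CC)C1=O` gives 3.26 uM. Compound 3 `CCC1=C(O)c2c(oc(-c3ccc(OC)cc3C)cc2=O)C(CC)(CC)C1=O` gives 2.62 uM. Compound 3 thus stands second highest of the three numbers, nearest to compound 2 and furthest from compound 1; the steps were a 3.0-fold higher number from compound 1 to compound 2 (0.48 log units; beyond the scatter), a 2.4-fold higher number from compound 1 to compound 3 (0.38 log units; beyond the scatter) and a 1.2-fold lower number from compound 2 to compound 3 (0.09 log units; within the scatter). Compound 4 `CCC1=C(O)c2c(oc(-c3cc(C)ccc3F)cc2=O)C(CC)(CC)C1=O` differs from compound 3 by 2-fluoro-5-methylphenyl in place of 4-methoxy-2-methylphenyl on an aromatic carbon. For the measured compounds named here, no measured step exchanges a methoxy for a fluorine, so only the modest spread among compounds 1 to 3 bears on it; the change is expected to give a 1.1-fold higher number from compound 3 to compound 4 (0.06 log units; within the scatter), hardly beyond the scatter. Compound 4 is estimated at 3 uM, within 1.2 uM to 7.5 uM.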

Compound 4, concentration for half-maximal effect: 3.24 uM
For compound 4 the middle estimate is 1.1-fold (0.03 log units) below the measured one; measured number inside the range.
By their numbers in this assay, from the lowest: compound 1; then compounds 3, 4 and 2 (each within the scatter of the next).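

With 2-fluoro-5-methylphenyl in this position, which has no oxygen, the number stays within the scatter of both methoxy-bearing analogues (a 1.2-fold higher number from compound 3 to compound 4 (0.09 log units; within the scatter); a 1.0-fold lower number from compound 2 to compound 4 (0.00 log units; within the scatter)). Among the compounds shown, a methoxy group on the aryl ring is therefore not required for activity at this level, while the gap to the 4-isopropylphenyl analogue remains beyond the scatter (a 3.0-fold higher number from compound 1 to compound 4 (0.48 log units; beyond the scatter)). Nothing available explains either result. Open, on these data alone, is whether the lower number of compound 1 belongs to the isopropyl group itself, and how a phenyl carrying an amine or a carboxylic acid would read.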